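Crotonamide Versus Butynamide on a Shared Triazine Core

This account rests on a few compounds, and the source may have more. Where it says the series, first, only, none or still open, it means among the compounds named here.

Compounds measured so far:
compound 1, `C=CC(=O)Nc1cccc(Nc2ncnc(Nc3ccc(C(=O)N4CCCCC4)cc3)n2)c1`, 5140 nM in a functional assay on Raji cells (Homo sapiens) for antiproliferative activity, read by CCK-8 assay, with a stated time of 24 h; on this read-out lower numbers stand for stronger inhibition and higher numbers for weaker inhibition
compound 2, `CC#CC(=O)Nc1cccc(Nc2ncnc(Nc3ccc(C(=O)N4CCCCC4)cc3)n2)c1`, 4620 nM in this assay

Two compounds of this series have been run in this assay. Compound 1 gives 5140 nM, and compound 2 gives 4620 nM. The step of a 1.1-fold lower number from compound 1 to compound 2 (0.05 log units; within the scatter) is the only one between them, so on the numbers shown compound 2 and compound 1 cannot be told apart, and neither can be called the stronger.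

The next compound, compound 3 with the structure `C/C=C/C(=O)Nc1cccc(Nc2ncnc(Nc3ccc(C(=O)N4CCCCC4)cc3)n2)c1`, differs from compound 2 in one place: prop-1-en-1-yl in place of prop-1-yn-1-yl on a carbonyl carbon. Within the data shown here, the one measured step, a 1.1-fold lower number from compound 1 to compound 2 (0.05 log units; within the scatter), also altered this same group on the carbonyl carbon and left the number essentially unchanged. Nothing in the data points to a larger effect for the present change.

Compound 3 is therefore expected to sit close to compound 2, with a step of a 1.1-fold higher number from compound 2 to compound 3 (0.03 log units; within the scatter) in this assay that stays within the scatter. The estimate for compound 3 is 5000 nM, with a range from 2500 nM to 10000 nM.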

Compound 3, half-maximal inhibitory concentration: 13800 nM
Beside the measured number, compound 3's estimate is 2.8-fold (0.44 log units) below it; measured number outside the range, above it.
By their numbers in this assay, from the lowest: compounds 2 and 1 (each within the scatter of the next); then compound 3.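

In this assay the group on the carbonyl carbon proves not to be indifferent to change: prop-1-en-1-yl brings a 3.0-fold higher number from compound 2 to compound 3 (0.48 log units; beyond the scatter) when it replaces prop-1-yn-1-yl and a 2.7-fold higher number from compound 1 to compound 3 (0.43 log units; beyond the scatter) when it replaces vinyl. The earlier exchange of vinyl for prop-1-yn-1-yl, a 1.1-fold lower number from compound 1 to compound 2 (0.05 log units; within the scatter) and thus within the scatter, gave no sign that this place could move the number at all. Compound 2 and compound 3 carry groups with the same count of 3 carbon atoms, differing in a triple against a double bond, so the carbon count of the group does not by itself fix the number, and nothing available gives a reason for the difference.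

The compounds shown leave open whether a saturated propyl group, or a dimethylamino group on the end of the prop-1-en-1-yl chain, would stand with compound 3 or with compound 1 and compound 2. On these data alone, all three compounds also share one core, so whether the same step appears on any other core remains unknown.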